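A few compounds are considered here, and "the series" means these few. Any claim that something is new, unique, unknown or untested is made for them only; others in the source may bear on it.

Measured compounds in a functional assay on DU-145 cells (Homo sapiens) for antiproliferative activity, read by sulforhodamine B assay, with a stated time of 72 h; a higher number here means a weaker inhibitor of growth, a lower number a stronger inhibitor of growth:
compound 1 `Cc1cc(=O)oc2cc(Sc3cccc(Cl)n3)ccc12` — 1150 nM
compound 2 `Cc1cc(=O)oc2cc(SCc3cccc(C(F)(F)F)c3)ccc12` — > 28500 nM
compound 3 `Cc1cc(=O)oc2cc(SCc3cccc(C#N)c3)ccc12` — > 32500 nM

Of the three, only compound 1 gives a number in this assay, 1150 nM. For compound 2 this assay reports a limit only, > 28500 nM. For compound 3 it likewise reports a limit only, > 32500 nM. Compound 3 thus stands at one of two limits in the set, with no number of its own; the other limit is that of compound 2. For the measured compounds named here, the one single-point step among the measured compounds, a step that the two limits leave unreadable from compound 2 to compound 3, is left unreadable by the two limits (the limit of > 28500 nM in this assay, at which 1 of the 3 values shown sits, (the limit of > 32500 nM in this assay, at which 1 of the 3 values shown sits)).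

Compound 4 `COC(=O)c1cccc(CSc2ccc3c(C)cc(=O)oc3c2)c1` differs from compound 3 in one place: methoxycarbonyl in place of cyano on an aromatic carbon. Going by the values given here, no measured step bears directly on this exchange; the only step between neighbours in the set is the unreadable one from compound 2 to compound 3, and compound 1 carries a different link and a different ring, so it yields no step to compound 3. The expectation for compound 4 therefore rests only on compound 3 standing at a limit of this assay: the step of an at least 1.0-fold lower number from compound 3 to compound 4 (0.03 log units; that floor lies within the scatter) is expected to be none beyond the scatter, with the result most likely again a limit. For compound 4 in this assay the estimate is 30000 nM, between 6000 nM and 100000 nM.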

Compound 4, concentration for 50% growth inhibition: 14100 nM
The estimate for compound 4 lay 2.1-fold (0.33 log units) above the measured number, within the range that was stated.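

For the compounds shown here, at the place described as an aromatic carbon of a six-membered aromatic ring of carbon only, meta to a large group, methoxycarbonyl gives the first number among the three compounds that differ only there, so the group at this place can move the read-out in this assay. Replacing cyano gives an at least 2.3-fold lower number from compound 3 to compound 4 (0.36 log units; beyond the scatter), while replacing trifluoromethyl gives an at least 2.0-fold lower number from compound 2 to compound 4 (0.30 log units; that floor lies within the scatter), a floor that does not by itself clear the scatter. Compound 2 and compound 3 stand only at limits, so both new steps are floors and the step between those two compounds cannot be read.

As far as these compounds go, the true size of either step stays open, as does whether the change in this assay follows the whole methoxycarbonyl group or only its carbonyl, a question that a carboxylic acid or a primary amide at the same place would bear on. From the compounds shown here alone, compound 1 differs from compound 4 in more than one place, so the separate contributions of the link and the ring also remain open.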